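This account rests on a few compounds, and the source may have more. Where it says the series, first, only, none or still open, it means among the compounds named here.

Compound 2 `CC#C[C@H]1CN(S(=O)(=O)c2ccc(N)nc2)CCN1c1ccc(C(O)(COC)C(F)(F)F)cc1` stands lowest among the three measured compounds. In an assay on cells (Hepatocyte) for inhibition of glucokinase regulatory protein (Mus musculus), with stated times of 20 min and 40 min (a higher number here means that more compound is needed for the effect, a lower number that less compound is needed), compound 2 gives 202 nM. Compound 1 `CC#C[C@H]1CN(S(=O)(=O)c2ccc(N)nc2)CCN1c1ccc(C(C)(O)C(F)(F)F)nc1` gives 1450 nM in this assay, and compound 3 `CC#C[C@H]1CN(S(=O)(=O)c2ccc(N)nc2)CCN1c1ncc(C(O)(C(F)(F)F)C(F)(F)F)cn1` gives 2200 nM; both numbers lie beyond the scatter of that of compound 2, so compound 2 needs the least compound of the three. Compound 4 `CC#C[C@H]1CN(S(=O)(=O)c2ccc(N)nc2)CCN1c1ccc(C(=O)NC)cc1` has not yet been measured. It differs from compound 2 by a group of 4 heavy atoms (2 carbon, 1 nitrogen, 1 oxygen; no ring) in place of a group of 9 heavy atoms (4 carbon, 2 oxygen, 3 fluorine; no ring), on an aromatic carbon. For the measured compounds named here, no measured pair shows this change, so its effect is open; a replacement of this size is expected to move the number beyond the scatter, most likely upward, meaning more compound needed. The estimated step is a 5.0-fold higher number from compound 2 to compound 4 (0.69 log units; beyond the scatter). Compound 4 is expected to give 1000 nM in this assay, within a range from 300 nM to 4000 nM.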

Compound 4, half-maximal effective concentration: 4050 nM
The estimate for compound 4 lay 4.1-fold (0.61 log units) below the measured number, outside the stated range (above it).
By their numbers in this assay, from the lowest: compound 2; then compounds 1, 3 and 4 (each within the scatter of the next, the first and the last beyond it).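

This position, on an aromatic carbon para to a large group, turns out to matter a great deal: in this assay, methylcarbamoyl in place of the group of 9 heavy atoms brings a 20-fold higher number from compound 2 to compound 4 (1.30 log units; beyond the scatter). Both groups carry a hydrogen-bond donor, so a donor alone does not keep the number low here. Nothing measured here accounts for this rise.

Going by these compounds, whether a carboxylic acid or an amide with a longer chain at this position would fall nearer compound 2 or compound 4 remains open. Also open, on these data alone, is which part of the larger group matters most.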